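The source may report more compounds than this note shows. Statements on the series, on what has been measured and on what is new or still open speak of the compounds shown alone.

Working notes on a small set tested in an assay on isolated protein for inhibition of MAP kinase-activated protein kinase 2 (Homo sapiens), read by HTRF, tested at 10 uM; on this read-out higher numbers stand for more inhibition at the one concentration tested (going by the name of the read-out) and lower numbers for less inhibition.

Compound 1 is `Cc1cccc(N(C)c2cc(Nc3cccc(C(=O)N4CCCC5CCCCC54)c3)ncn2)c1`. In this assay compound 1 gives 0%. Compound 2 is `Clc1ccc2sc(CN3CCN(c4ncnc5c4CN(Cc4ccccc4)CC5)CC3)cc2c1`. In this assay compound 2 gives 1%. These two numbers lie within the scatter of each other, so neither compound can be set apart from the other on this read-out; both sit at the foot of the scale, with essentially no inhibition recorded at the one concentration tested. Among the compounds with values here, no step between measured compounds differing in a single place is available within the set.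

Compound 3 is `O=C(CN1CCN(c2ncnc3c2CN(Cc2ccccc2)CC3)CC1)Nc1cc(F)ccc1F`, not yet measured in this assay. It shares its core with compound 2 and differs from it as follows: (2,5-difluorophenyl)carbamoyl in place of 5-chloro-1-benzothiophen-2-yl on a saturated chain carbon bound to an amine nitrogen in a ring. Within the data shown here, no measured pair shows what this kind of replacement does here, so the expectation rests only on the level at which compound 2 stands. The step from compound 2 to compound 3 is expected to be a number 1 percentage points higher from compound 2 to compound 3 (within the scatter), that is, no change beyond the scatter in either direction. Compound 3 is therefore expected to come in at about 2%, with a range of -8% to 15%.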

Compound 3, a percentage reported as inhibition, at one concentration (the size of the read-out at that concentration, not a potency): 0%
Estimate against measurement, compound 3: 2 percentage points above, and the stated range covers the measured number.
By their numbers in this assay, from the lowest: compounds 1, 3 and 2 (each within the scatter of the next).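

In this assay, within the data shown here, putting (2,5-difluorophenyl)carbamoyl in place of 5-chloro-1-benzothiophen-2-yl on a saturated chain carbon bound to an amine nitrogen in a ring gives a number 1 percentage points lower from compound 2 to compound 3 (within the scatter) and so provides the first one-place comparison. The exchange is a substantial one in structure: a fused pair of aromatic rings carrying sulfur and chlorine leaves, and a single fluorinated benzene ring enters with a carbonyl and the amide hydrogen, yet the read-out stays at the foot of the scale. No measurement at hand bears on why the result falls there.

With both compounds at the foot of the scale, this one step cannot show whether this position has any influence on inhibition at the one concentration tested, or whether the shared core sets the level regardless of the group placed there. Also open, from the compounds shown here alone, is how a primary amine, a carboxylic acid or a longer chain ending in a phenyl ring would read at this same place on the shared core.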